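Swapping the butyl chain for a sulfur ring

The source may hold more compounds than are shown below. What is called first, only, known or untested is meant among the compounds shown, and "the series" means these compounds.

Three compounds share one core and were tested in an assay (strain Wistar) for inhibition of Hormone-sensitive lipase (Rattus norvegicus), read by spectrophotometry; a higher number here means a weaker inhibitor, a lower number a stronger inhibitor. Compound 1 `Cc1c(C(C)C)c(=O)on1C(=O)N(C)c1ccc(Cl)cc1` gives 17 nM, compound 2 `Cc1c(C(C)C)c(=O)on1C(=O)N1CCOCC1` gives 52 nM, and compound 3 `CCCCc1c(C)n(C(=O)N2CCC(C)CC2)oc1=O` gives 1 nM, the lowest of the three and beyond the scatter from both others, so compound 3 is the strongest inhibitor of the set. Compound 4 `Cc1c(C2CCSCC2)c(=O)on1C(=O)N1CCC(C)CC1` differs from compound 3 in one place: thian-4-yl in place of butyl on an aromatic carbon. Within the data shown here, no pair of measured compounds shows this kind of swap, so its effect is unknown. A small weakening is expected from compound 3 to compound 4, roughly a 3.0-fold higher number from compound 3 to compound 4 (0.48 log units; beyond the scatter), with the chance that the step stays within the scatter. Compound 4 is therefore estimated at 3 nM, within 1 nM to 10 nM.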

Compound 4, half-maximal inhibitory concentration: 6 nM
For compound 4 the middle estimate is 2.0-fold (0.30 log units) below the measured one, within the range that was stated.
By their numbers in this assay, from the lowest: compound 3; then compound 4; then compound 1; then compound 2.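

In this assay the swap gives a 6.0-fold higher number from compound 3 to compound 4 (0.78 log units; beyond the scatter), a modest loss of strength. This aromatic carbon therefore accepts a six-membered ring containing sulfur in place of an open butyl chain, and the inhibitor remains in the low nanomolar range. No measurement here accounts for the size of this step. From the compounds shown here alone, the swap changes the chain, the ring and the sulfur atom all at once, so the share of each remains unknown. A cyclohexyl ring or a pentyl chain at this position would help to separate them.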